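The source may report more compounds than this note shows. Statements on the series, on what has been measured and on what is new or still open speak of the compounds shown alone.

Measured so far:
compound 1, `Cc1cc(-n2nccn2)cc(C(=O)NNS(=O)(=O)c2ccccc2)c1F`: 28 uL/min
compound 2, `O=C(NNS(=O)(=O)c1ccccc1F)c1cc(F)cc(-c2ccccn2)c1`: 31 uL/min

In an ADME assay on microsomes from liver (Homo sapiens) for metabolic stability, read by HPLC, using NADPH, with a stated time of 60 min, tested at 1 uM, in the presence of a further agent that is not named here (on this read-out lower numbers stand for slow clearance and higher numbers for fast clearance), compound 1 gives 28 uL/min, the smaller of the two numbers, and compound 2 gives 31 uL/min; the gap between them lies within the usual scatter, so the two are not separable on this read-out. Compound 3, `Cc1cc(-n2cccn2)cc(C(=O)NNS(=O)(=O)c2ccccc2)c1F`, has not been measured. It differs from compound 1 by 1H-pyrazol-1-yl in place of 2H-1,2,3-triazol-2-yl on an aromatic carbon. For the measured compounds named here, no measured pair shows this change, so there is no step to lean on. The expected step of a 1.3-fold higher number from compound 1 to compound 3 (0.10 log units; within the scatter) is small, none beyond the scatter or a slight rise. Compound 3 is estimated at 35 uL/min, in a range from 17 uL/min to 70 uL/min.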

Compound 3, intrinsic clearance in a liver preparation (reported as CLH), per the amount of preparation that the assay uses in the Homo sapiens assay: 23 uL/min
Compound 3: middle estimate off by 1.5-fold (0.18 log units), on the high side, and the stated range covers the measured number.
By their numbers in the Homo sapiens assay, from the lowest: compounds 3, 1 and 2 (each within the scatter of the next).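

At this aromatic carbon, 1H-pyrazol-1-yl in place of 2H-1,2,3-triazol-2-yl does not separate the pair in the Homo sapiens assay, with a 1.2-fold lower number from compound 1 to compound 3 (0.09 log units; within the scatter). In a physicochemical assay for solubility, read by nephelometry, in phosphate buffer, measured as kinetic solubility, at pH 6.5 (on this read-out higher numbers stand for higher solubility and lower numbers for lower solubility), compound 1 gives 25 ug/mL and compound 3 gives 6.3 ug/mL. Read in the physicochemical assay, that is a 4.0-fold lower number from compound 1 to compound 3 (0.60 log units; beyond the scatter), so this pair parts on that read-out alone.

Going by these compounds, how an amine or a carboxylic acid on this aromatic carbon would read on either measure stays open. A single pair also cannot tell whether the same step holds on another core.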